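Amino in Place of Methyl on a Shared Core

The source may report more compounds than this note shows. Statements on the series, on what has been measured and on what is new or still open speak of the compounds shown alone.

Of the compounds shown here, three sharing one core have been tested in a functional assay on K562 cells (Homo sapiens), read by MTT assay, with a stated time of 72 h (on this read-out lower numbers stand for stronger inhibition and higher numbers for weaker inhibition), and none gave a number. Compound 1, `Nc1nc(N)c2c(-c3ccsc3)cn([C@@H]3O[C@H](CO)[C@@H](O)[C@H]3O)c2n1`, reached only the limit of the assay, > 20000 nM. Compound 2, `COc1nc(N)nc2c1c(-c1ccoc1)cn2[C@@H]1O[C@H](CO)[C@@H](O)[C@H]1O`, likewise stopped at the limit, > 20000 nM. Compound 3, `Cc1nc(N)c2c(-c3ccoc3)cn([C@@H]3O[C@H](CO)[C@@H](O)[C@H]3O)c2n1`, also gave only the limit, > 20000 nM. Going by the values given here, because every value is a limit rather than a number, no step between two measured compounds can be drawn; the single piece of evidence is the limit of > 20000 nM in this assay, at which 3 of the 3 values shown sit, a limit that all three compounds share.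

The untested compound 4, `Nc1nc(N)c2c(-c3ccoc3)cn([C@@H]3O[C@H](CO)[C@@H](O)[C@H]3O)c2n1`, differs from compound 3 in one place: amino in place of methyl on an aromatic carbon. Two amino groups on the core already occur in compound 1, which in this assay gave a limit, > 20000 nM. Among the compounds with values here, nothing among the measured compounds points toward a gain in potency from this change.

The expected step is therefore a step that the limit leaves unreadable from compound 3 to compound 4, that is, none beyond the usual scatter. Compound 4 is estimated to give 25000 nM, within a range from 8000 nM to 80000 nM, with the most likely outcome being yet another limit rather than a number.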

Compound 4, half-maximal inhibitory concentration: > 20000 nM
Compound 4: no number, only a limit; the forecaster's own chance of this, stated with the estimate: 85%; the middle value does not contradict the limit.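

In this assay compound 4 gives > 20000 nM and this is a limit of the assay, not a number. Its steps from compound 1, compound 2 and compound 3 therefore cannot be read: the limit of > 20000 nM in this assay, at which 4 of the 4 values shown sit. The compounds shown leave open how far apart these four truly lie, and whether any change on the shared core would give a measurable value.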